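Acid versus hydroxamate at the chain end of the macrocycle

This account rests on a few compounds, and the source may have more. Where it says the series, first, only, none or still open, it means among the compounds named here.

Measured compounds in a functional assay on MDA-MB-231 cells (Homo sapiens) for antiproliferative activity, read by MTT assay, with a stated time of 72 h; on this read-out higher numbers stand for weaker inhibition and lower numbers for stronger inhibition:
- compound 1, `O=C(O)CCCCCOc1ccc2cc1COC/C=C/COCc1cccc(c1)-c1ccnc(n1)N2`: 19900 nM
- compound 2, `O=C(O)c1cccc(NCCOc2ccc3cc2COC/C=C/COCc2cccc(c2)-c2ccnc(n2)N3)c1`: 21400 nM
- compound 3, `O=C(CCCCCOc1ccc2cc1COC/C=C/COCc1cccc(c1)-c1ccnc(n1)N2)NO`: 8070 nM

Compound 3 gives the lowest number of the three. Its step from compound 1 is a 2.5-fold lower number from compound 1 to compound 3 (0.39 log units; beyond the scatter), and from compound 2 it is a 2.7-fold lower number from compound 2 to compound 3 (0.42 log units; beyond the scatter); both steps are beyond the scatter, so compound 3 stands apart from the two acids. Between the acids themselves the step is a 1.1-fold higher number from compound 1 to compound 2 (0.03 log units; within the scatter), so compound 1 and compound 2 cannot be ordered on this read-out.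

Compound 4, `O=C(O)CCCCCCOc1ccc2cc1COC/C=C/COCc1cccc(c1)-c1ccnc(n1)N2`, is not yet measured. Its difference from compound 3 is carboxymethyl in place of hydroxycarbamoyl on a saturated chain carbon, five bonds along the chain from an oxygen on an aromatic ring.

The step that bears on this change is a 2.5-fold lower number from compound 1 to compound 3 (0.39 log units; beyond the scatter), which runs in the opposite direction: there the hydroxyamino group on the carbonyl carbon replaced hydroxy and the number fell. Compound 4 returns to a carboxylic acid end, one chain carbon longer than in compound 1, so the expectation is that the step of a 2.5-fold higher number from compound 3 to compound 4 (0.39 log units; beyond the scatter) undoes that gain. Compound 4 is therefore expected to give about 20000 nM in this assay, within a range of 8000 nM to 50000 nM.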

Compound 4, half-maximal inhibitory concentration: 12000 nM
Estimate against measurement, compound 4: 1.7-fold (0.22 log units) above, and the stated range covers the measured number.
By their numbers in this assay, from the lowest: compounds 3, 4, 1 and 2 (each within the scatter of the next, the first and the last beyond it).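

Carboxymethyl in place of hydroxycarbamoyl, five bonds along the chain from an oxygen on an aromatic ring, gives a 1.5-fold higher number from compound 3 to compound 4 (0.17 log units; within the scatter) in this assay, so this acid end is not separated from the hydroxamate end, as the acid ends of compound 1 and compound 2 were. Carboxymethyl in place of carboxy gives a 1.7-fold lower number from compound 1 to compound 4 (0.22 log units; within the scatter), and 4-carboxybutyl in place of (3-carboxyphenyl)amino gives a 1.8-fold lower number from compound 2 to compound 4 (0.25 log units; within the scatter), so compound 4 cannot be ordered against either earlier acid. No measurement offered here accounts for these steps.

From the compounds shown here alone, what a hydroxycarbamoyl group would give on the chain of compound 4 remains open. So does what a longer chain ending in a carboxylic acid, or a chain of this length ending in an amine, would give.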